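Swapping nitro for amino in an antiproliferative series

This account rests on a few compounds, and the source may have more. Where it says the series, first, only, none or still open, it means among the compounds named here.

Measured so far:
Compound 1 `O=C(N/N=C/c1ccccn1)c1ccc(C(F)(F)F)cc1` gives 22400 nM in an ADME assay on cells (Homo sapiens) for antiproliferative activity, read by MTT assay; on this read-out lower numbers stand for stronger inhibition and higher numbers for weaker inhibition.
Compound 2 `C/C(=N\NC(=O)c1ccc([N+](=O)[O-])cc1)c1cnccn1` gives 1390 nM in this assay.
Compound 3 `O=C(N/N=C/c1ccccn1)c1cccc(Br)c1` gives 13500 nM in this assay.

Among these three numbers compound 2 stands lowest, and its distance to both neighbours is beyond the usual scatter of the assay: compound 3 is the nearest of the two, compound 1 the furthest. Among the compounds with values here, none of the three compounds differs from another in a single place, so no measured step shows what one isolated change does to the read-out in this assay.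

Compound 4 `C/C(=N\NC(=O)c1ccc(N)cc1)c1cnccn1` has not yet been tested. Its difference from compound 2 is amino in place of nitro on an aromatic carbon. Within the data shown here, with no comparable step available among the measured compounds, the expectation for this change can rest only on the standing of compound 2 itself. The writer expects a modest loss in this assay, that is a step from compound 2 to compound 4 of about a 2.9-fold higher number from compound 2 to compound 4 (0.46 log units; beyond the scatter), toward a higher number, somewhat beyond the scatter but not large. On that basis compound 4 is estimated to give about 4000 nM in this assay, within a range from 1000 nM to 16000 nM.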

Compound 4, half-maximal inhibitory concentration: 58800 nM
The estimate for compound 4 lay 15-fold (1.17 log units) below the measured number, outside the stated range (above it).
By their numbers in this assay, from the lowest: compound 2; then compounds 3 and 1 (each within the scatter of the next); then compound 4.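

In this assay, within the data shown here, the amino-for-nitro swap gives the first single-place comparison in this set, and a 42-fold higher number from compound 2 to compound 4 (1.63 log units; beyond the scatter) is a large step. It shows that the group on this aromatic carbon, para to a large group, can on its own move the read-out far beyond the scatter while the rest of the structure stays the same, and that, of these two groups, nitro goes with the stronger inhibition on this core. No measurement at hand bears on the cause of this step, so its size stands here without an explanation.

What the compounds shown leave open is whether the outcome is specific to nitro and amino or forms part of a wider trend at this carbon, and how a methoxy group, a nitrile, a carboxylic acid or an acetamide would stand there. It also remains open whether the same swap would produce a step of similar size on the core of compound 1 or compound 3, where no such pair is shown.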